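Deacetylation step from compound 3 to compound 4

The compounds below may be only part of what the source reports. "The series", "measured", "known", "first", "only" and "open" are said of these compounds alone.

Of the compounds shown here, three have been measured in a functional assay on MCF7 cells (Homo sapiens) for antiproliferative activity; a lower number here means a stronger inhibitor, a higher number a weaker inhibitor. Compound 1 `CC(=O)Oc1ccc(C(=O)Nc2cc3ccc(OCC4CCCN(C)C4)c(C)c3oc2=O)cc1CC=C(C)C` gives 1650 nM and compound 2 `CC(=O)Oc1ccc(C(=O)Nc2cc3ccc(OCC4CCN(C)C4)c(C)c3oc2=O)cc1CC=C(C)C` gives 1880 nM; the change between them, a 1.1-fold higher number from compound 1 to compound 2 (0.06 log units; within the scatter), stays inside the scatter. Compound 3 `CC(=O)Oc1ccc(C(=O)Nc2cc3ccc(OCC4CCCNC4)c(C)c3oc2=O)cc1CC=C(C)C` gives 820 nM, the lowest of the three numbers; its nearest neighbour is reached by a 2.0-fold lower number from compound 1 to compound 3 (0.30 log units; within the scatter), its furthest by a 2.3-fold lower number from compound 2 to compound 3 (0.36 log units; beyond the scatter), and only the latter passes beyond the scatter, so the three values sit close together.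

Compound 4 `CC(C)=CCc1cc(C(=O)Nc2cc3ccc(OCC4CCCNC4)c(C)c3oc2=O)ccc1O` is the next step from compound 3: hydrogen in place of acetyl on an oxygen on an aromatic ring. Among the measured compounds shown here, every measured step so far concerns the amine ring rather than the acetyl, so no measured step bears directly on this change, and the three steps, all small, give no guidance on direction. The default expectation is therefore a step of a 1.2-fold lower number from compound 3 to compound 4 (0.07 log units; within the scatter), not beyond the scatter, with a wide range to reflect the absence of any precedent in the series. Compound 4 is estimated at 700 nM in this assay, between 250 nM and 2000 nM.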

Compound 4, half-maximal inhibitory concentration: 790 nM
Compound 4: the middle estimate sits 1.1-fold (0.05 log units) below what was measured; low and high end bracket the measured number.
By their numbers in this assay, from the lowest: compounds 4, 3, 1 and 2 (each within the scatter of the next, the first and the last beyond it).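

In this assay, the first change read away from the amine ring, acetoxy to hydroxy on the aromatic ring, gives a 1.0-fold lower number from compound 3 to compound 4 (0.02 log units; within the scatter), a step that stays within the scatter. With the piperidin-3-yl side chain in place, the acetyl and its three heavy atoms can therefore leave this oxygen with no readable shift in the number, so the acetyl is not needed to hold antiproliferative activity at the level of compound 3. No data are available to explain why this exchange leaves the number unchanged within the scatter.

This single pair does not show whether the same exchange would be as silent with the 1-methylpiperidin-3-yl side chain of compound 1 or the 1-methylpyrrolidin-3-yl side chain of compound 2, so the tolerance at this oxygen is established for one amine ring only. On these data alone, it also remains open whether this oxygen tolerates groups of a different kind, such as a methyl ether, a longer acyl chain like butanoyl, or a chain ending in a carboxylic acid, or whether one of these would move the number beyond the scatter.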